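The source may report more compounds than this note shows. Statements on the series, on what has been measured and on what is new or still open speak of the compounds shown alone.

In a functional assay on HeLa cells (Homo sapiens) for inhibition, read by CCK-8 assay, with a stated time of 72 h (a higher number here means a weaker inhibitor, a lower number a stronger inhibitor), compound 1 (`O=C(/C=C/c1cccnc1)NCCCCc1ccc(S(=O)(=O)Nc2ccccc2)cc1`) gives 184 nM, compound 2 (`O=C(/C=C/c1cccnc1)NCCCc1cccc(S(=O)(=O)Nc2ccccc2)c1`) gives 115 nM and compound 3 (`Cc1ccccc1NS(=O)(=O)c1cccc(CCCCCCNC(=O)/C=C/c2cccnc2)c1`) gives 2.34 nM. Compound 3 therefore has the lowest of the three numbers, and its gaps to the other two lie well beyond the usual scatter. Compound 4 (`O=C(/C=C/c1cccnc1)NCCCCCCc1cccc(S(=O)(=O)Nc2ccc(F)c(Cl)c2)c1`) has 3-chloro-4-fluorophenyl in place of 2-methylphenyl on a sulfonamide nitrogen. For the measured compounds named here, no measured pair isolates a change at this place, so the expectation is only tentative. With compound 3 already at 2.34 nM, a modest rise seems likelier than a further fall. The expected change is a 2.6-fold higher number from compound 3 to compound 4 (0.41 log units; beyond the scatter), which would mean a somewhat weaker inhibitor. For compound 4, the estimated value is 6 nM, with an expected range from 1.2 nM to 30 nM.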

Compound 4, half-maximal inhibitory concentration: 385 nM
Estimate against measurement, compound 4: 64-fold (1.81 log units) below; the measured number lies above the stated range.
By their numbers in this assay, from the lowest: compound 3; then compounds 2 and 1 (each within the scatter of the next); then compound 4.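

For the compounds shown here, compound 3 and compound 4 are the first measured pair to isolate the group on the sulfonamide nitrogen. In this assay, 3-chloro-4-fluorophenyl in place of 2-methylphenyl gives a 160-fold higher number from compound 3 to compound 4 (2.22 log units; beyond the scatter), so the low number of compound 3 depends strongly on this group and not on the rest of the molecule alone. Nothing measured here explains the size of this loss.

The pair cannot separate losing the methyl group from gaining the chlorine or the fluorine. On these data alone, how a cyclohexyl group on this nitrogen would compare also remains open.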